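Extending the amide chain of compound 2 toward compound 4

A few compounds are considered here, and "the series" means these few. Any claim that something is new, unique, unknown or untested is made for them only; others in the source may bear on it.

Measured compounds:
compound 1, `O=C(Nc1cc(Oc2ccc(Nc3nccc4[nH]cc(-c5ccc(F)cc5)c(=O)c34)cc2F)ccn1)C1CCC1`: 46%
compound 2, `CC(=O)Nc1cc(Oc2ccc(Nc3nccc4[nH]cc(-c5ccc(F)cc5)c(=O)c34)cc2F)ccn1`: 36.8%
compound 3, `CCC(=O)Nc1cc(Oc2ccc(Nc3nccc4[nH]cc(-c5ccc(F)cc5)c(=O)c34)cc2F)ccn1`: 68.7%

All three share one core and differ only in the group on the amide carbonyl. In a functional assay on HT-29 cells (Homo sapiens) for antiproliferative activity, read by MTT assay, with a stated time of 72 h, tested at 10 uM (on this read-out higher numbers stand for more inhibition at the one concentration tested (going by the name of the read-out) and lower numbers for less inhibition), compound 2 gives the lowest of the three numbers; the steps of a number 9.2 percentage points lower from compound 1 to compound 2 (within the scatter) and a number 31.9 percentage points higher from compound 2 to compound 3 (beyond the scatter) set it against the other two. The unmeasured compound 4, `CCCC(=O)Nc1cc(Oc2ccc(Nc3nccc4[nH]cc(-c5ccc(F)cc5)c(=O)c34)cc2F)ccn1`, differs from compound 2 as follows: ethyl in place of hydrogen on a saturated chain carbon bound to a carbonyl carbon. For the measured compounds named here, two steps bear on this. The step of a number 31.9 percentage points higher from compound 2 to compound 3 (beyond the scatter) shows a large gain when the chain grows by one carbon; the step of a number 22.7 percentage points higher from compound 1 to compound 3 (beyond the scatter) shows that cyclobutyl falls short of ethyl. Compound 4 is therefore expected to rise above compound 2, by roughly a number 21.2 percentage points higher from compound 2 to compound 4 (beyond the scatter), landing near 58% with a range from 36% to 80%.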

Compound 4, a percentage reported as inhibition, at one concentration (the size of the read-out at that concentration, not a potency): 23.5%
Estimate against measurement, compound 4: 34.5 percentage points above, outside the stated range (below it).
By their numbers in this assay, from the lowest: compound 4; then compounds 2 and 1 (each within the scatter of the next); then compound 3.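

Read along the chain on the amide carbonyl in this assay, the numbers do not climb steadily: ethyl stands alone at the top, with a number 45.2 percentage points lower from compound 3 to compound 4 (beyond the scatter), and propyl falls even under methyl, with a number 13.3 percentage points lower from compound 2 to compound 4 (beyond the scatter). The open-chain propyl also trails the ring of cyclobutyl, with a number 22.5 percentage points lower from compound 1 to compound 4 (beyond the scatter), so one added carbon can reverse the gain seen earlier. Nothing available explains this reversal.

Still open, as far as these compounds go, is how a longer chain, such as pentyl, would read, and whether an amine on the chain would restore the number seen with ethyl.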